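The source may hold more compounds than are shown below. What is called first, only, known or untested is meant among the compounds shown, and "the series" means these compounds.

Working notes on the series. In a physicochemical assay for solubility, in phosphate buffer, at pH 7.4 (on this read-out lower numbers stand for lower solubility and higher numbers for higher solubility), compound 1 `CC(=O)N[C@@H]1CCC[C@H](C(=O)Nc2cc(-c3cnn(C)c3C)c(Cl)cn2)C1` gives 960000 nM, compound 2 `CC(=O)N[C@@H]1CCC[C@H](C(=O)Nc2cc(-c3cnn4ccccc34)c(Cl)cn2)C1` gives 45000 nM, and compound 3 `CC(=O)N[C@@H]1CCC[C@H](C(=O)Nc2cc(-c3cnc4ccccn34)c(Cl)cn2)C1` gives 120000 nM, the second highest of the three numbers. Compound 4 `CC(=O)N[C@@H]1CCC[C@H](C(=O)Nc2cc(-c3cnc4n3CCC4)c(Cl)cn2)C1` differs from compound 3 as follows: a group of 8 heavy atoms (6 carbon, 2 nitrogen; one five-membered non-aromatic ring with 1 hetero atom, one five-membered aromatic ring with 2 hetero atoms) in place of a group of 9 heavy atoms (7 carbon, 2 nitrogen; one five-membered aromatic ring with 2 hetero atoms, one six-membered aromatic ring with 1 hetero atom), on an aromatic carbon. Two measured steps bring in a six-membered aromatic ring, an 8.0-fold lower number from compound 1 to compound 3 (0.90 log units; beyond the scatter) and a 21-fold lower number from compound 1 to compound 2 (1.33 log units; beyond the scatter), while a 2.7-fold higher number from compound 2 to compound 3 (0.43 log units; beyond the scatter) separates the two groups carrying that ring. Compound 4 lacks that ring, as does compound 1 at 960000 nM, so a modest rise is expected in this assay, probably stopping short of compound 1. The expected step is a 3.2-fold higher number from compound 3 to compound 4 (0.50 log units; beyond the scatter). For compound 4 the estimated value is 380000 nM, with an expected range of 130000 nM to 1000000 nM.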

Compound 4, solubility: 490000 nM
Compound 4: the middle estimate sits 1.3-fold (0.11 log units) below what was measured; the range from low to high includes it.
By their numbers in this assay, from the lowest: compound 2; then compound 3; then compounds 4 and 1 (each within the scatter of the next).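

At this place, opposite the ring nitrogen, in this assay a five-membered non-aromatic ring in place of the six-membered aromatic ring gives a 4.1-fold higher number from compound 3 to compound 4 (0.61 log units; beyond the scatter) and an 11-fold higher number from compound 2 to compound 4 (1.04 log units; beyond the scatter) and shows that a two-ring group need not carry the lower numbers of compound 2 and compound 3. Among the compounds shown here, the second ring costs nothing measurable against the single ring of compound 1, since a 2.0-fold lower number from compound 1 to compound 4 (0.29 log units; within the scatter) stays within the scatter. No supporting data bear on the origin of these differences. Still open, as far as these compounds go, is how an amine or a carboxylic acid on the five-membered non-aromatic ring would read in this assay.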